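Cytotoxicity notes: amine-to-three-atom change on two cores

The source may report more compounds than this note shows. Statements on the series, on what has been measured and on what is new or still open speak of the compounds shown alone.

Compound 1, `CCC(CC)O[C@@H]1C=C(S(=O)(=O)O)C[C@H](N)[C@H]1NC(C)=O`, in an ADME assay on MDCK cells (Canis lupus familiaris) for cytotoxicity, with a stated time of 48 h (a higher number here means that more compound is tolerated, a lower number that less compound is tolerated), gives > 100000 nM, which is a limit of the assay and not a number.
Compound 2, `CCC(CC)O[C@@H]1C=C(S(=O)(=O)O)C[C@H](NC(=N)N)[C@H]1NC(C)=O`, in this assay gives > 100000 nM, again a limit rather than a number.
Compound 3, `CCCCOS(=O)(=O)C1=C[C@@H](OC(CC)CC)[C@H](NC(C)=O)[C@@H](N)C1`, in this assay gives "not determined" (no result reported), so no result is reported for it.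

The change from compound 1 to compound 2 is a group of 3 heavy atoms (1 carbon, 2 nitrogen; no ring) in place of a hydrogen atom, on an amine nitrogen. Its step, a step that the two limits leave unreadable from compound 1 to compound 2, cannot be sized because of the limit of > 100000 nM in this assay, at which 2 of the 3 values shown sit.

Compound 3 carries a different core: the difference from compound 1 is butyl in place of hydrogen on an oxygen.

Compound 4, `CCCCOS(=O)(=O)C1=C[C@@H](OC(CC)CC)[C@H](NC(C)=O)[C@@H](NC(=N)N)C1`, is not yet measured. It differs from compound 3 by a group of 3 heavy atoms (1 carbon, 2 nitrogen; no ring) in place of a hydrogen atom, on an amine nitrogen, the same change seen between compound 1 and compound 2, with the place described in identical words on both cores.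

Within the data shown here, no step from compound 3 to compound 4 can be stated, since compound 3 has no number. Among the measured compounds shown here, the only measured instance of this change left both ends at the limit, so compound 4 is expected to sit near that limit as well. The estimate for compound 4 in this assay is 150000 nM, with an expected range from 50000 nM to 500000 nM.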

Compound 4, half-maximal cytotoxic concentration: > 100000 nM
Compound 4 ended at the assay's limit (the forecaster's own chance of this, stated with the estimate: 80%); the middle value is on the limit's open side.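

No new step can be read from compound 2 to compound 4, since both values are a limit of the assay and not a number: the limit of > 100000 nM in this assay, at which 3 of the 4 values shown sit.

The compounds shown leave open whether butyl in place of hydrogen on an oxygen, or the group on the amine nitrogen, shifts tolerance in this assay at all.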